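Amino in place of fluoro on an aromatic carbon

A few compounds are considered here, and "the series" means these few. Any claim that something is new, unique, unknown or untested is made for them only; others in the source may bear on it.

Compound 1 `C=C(/C(C)=C/c1ccc(OC)c(O)c1)c1cc(OC)c(OC)c(OC)c1`: 89 nM
Compound 2 `C=C(/C(C)=C/c1ccc(OC)c(F)c1)c1cc(OC)c(OC)c(OC)c1`: 412 nM

In a functional assay on MCF7 cells (Homo sapiens) for antiproliferative activity, read by MTT assay, with a stated time of 48 h (on this read-out higher numbers stand for weaker inhibition and lower numbers for stronger inhibition), compound 2, at 412 nM, gives the higher of the two numbers and so the weaker inhibition. For the measured compounds named here, the only measured step is a 4.6-fold higher number from compound 1 to compound 2 (0.67 log units; beyond the scatter), and it is fluoro in place of hydroxy on an aromatic carbon.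

The next structure is compound 3 `C=C(/C(C)=C/c1ccc(OC)c(N)c1)c1cc(OC)c(OC)c(OC)c1`, which differs from compound 2 by amino in place of fluoro on an aromatic carbon. Going by the values given here, no compound with amino at this carbon has been measured, so the modest step above is the only evidence that bears on the change. It shows that this carbon's substituent matters, but it cannot say where amino will fall. The working expectation is that amino will give a result closer to the hydroxy of compound 1, which gives 89 nM, than to fluoro. The expected step is a 2.9-fold lower number from compound 2 to compound 3 (0.47 log units; beyond the scatter), towards stronger inhibition and of about the same size as the measured step. In this assay the estimated value for compound 3 is 140 nM, with an expected range of 45 nM to 430 nM.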

Compound 3, half-maximal inhibitory concentration: 356 nM
Estimate against measurement, compound 3: 2.5-fold (0.41 log units) below, and the stated range covers the measured number.
By their numbers in this assay, from the lowest: compound 1; then compounds 3 and 2 (each within the scatter of the next).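

In this assay, amino and fluoro on this carbon cannot be told apart (a 1.2-fold lower number from compound 2 to compound 3 (0.06 log units; within the scatter)), even though amino brings one hydrogen-bond donor and one hydrogen-bond acceptor and fluoro brings neither. Set against hydroxy, amino gives much the same picture as fluoro did (a 4.0-fold higher number from compound 1 to compound 3 (0.60 log units; beyond the scatter)), so compound 1 now stands clear of both compound 2 and compound 3 as the strongest inhibitor of the three, and the hydroxy result is no longer a contrast with fluoro alone. Nothing available accounts for why hydroxy separates from the other two groups at this carbon.

The three compounds leave open whether any other group on this carbon can reach the level of hydroxy, for instance hydroxymethyl, methylamino or an acetamide, or whether chloro or methyl would also sit with fluoro and amino. They also cannot say whether the separation of hydroxy from amino and fluoro holds on a different core or in any other cell line, since this one series in this one assay is all that is shown.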